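This account rests on a few compounds, and the source may have more. Where it says the series, first, only, none or still open, it means among the compounds named here.

In an ADME assay on HepG2 cells (Homo sapiens) for cytotoxicity, with a stated time of 72 h (on this read-out higher numbers stand for an effect only at larger amounts of compound and lower numbers for an effect already at smaller amounts), compound 3 `Cc1cc(NC(=O)Nc2cccc(N(C)C)c2)c2ccccc2n1` gives > 25000 nM, a limit of the assay and not a number. Compound 2 `Cc1cc(NC(=O)Nc2cccc(F)c2)c2ccccc2n1` gives > 25000 nM, also a limit. Compound 1 `COc1ccc(NC(=O)Nc2cc(C)nc3ccccc23)cc1OC`, which carries methoxy groups, gives > 25000 nM, again a limit. All three therefore share one result: the limit of > 25000 nM in this assay, at which 3 of the 3 values shown sit. Within the data shown here, the only measured step at this position, a step that the two limits leave unreadable from compound 2 to compound 3, has no readable size. Compound 4 `COc1cccc(NC(=O)Nc2cc(C)nc3ccccc23)c1` has methoxy in place of dimethylamino on an aromatic carbon. No compound here has yet shown a measurable effect, so a change beyond the scatter is not expected. The estimated change is a number no higher from compound 3 to compound 4 (the limit leaves the size open). For compound 4, the expected value is 25000 nM, with an estimated range from 12000 nM to 40000 nM.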

Compound 4, half-maximal effective concentration: > 25000 nM
Compound 4 ended at the assay's limit (the forecaster's own chance of this, stated with the estimate: 85%); the middle value lies on the limit itself.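

No step from compound 1, compound 2 or compound 3 to compound 4 can be read, because all four stop at one assay limit rather than a number: the limit of > 25000 nM in this assay, at which 4 of the 4 values shown sit.

The compounds shown leave open whether any of these groups changes the concentration at which an effect appears in this assay.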